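This account rests on a few compounds, and the source may have more. Where it says the series, first, only, none or still open, it means among the compounds named here.

Four related compounds share a common core and differ at two places. Compound 1 `COc1cc2c(Oc3ccc(NC(=O)c4nn(-c5ccccc5OC(F)(F)F)c(=O)cc4C)cc3F)ccnc2cc1OCCCN1CCC(C)CC1` and compound 2 `COc1cc2c(Oc3ccc(NC(=O)c4nn(-c5ccccc5OC(F)(F)F)c(=O)cc4C)cc3F)ccnc2cc1OCCCN1CCN(C)CC1` carry one end group; compound 3 `COc1ccc(-n2nc(C(=O)Nc3ccc(Oc4ccnc5cc(OCCCN6CCC(C)CC6)c(OC)cc45)c(F)c3)c(C)cc2=O)cc1` and the as yet unmeasured compound 4 `COc1ccc(-n2nc(C(=O)Nc3ccc(Oc4ccnc5cc(OCCCN6CCN(C)CC6)c(OC)cc45)c(F)c3)c(C)cc2=O)cc1` carry another, the difference between the two cores being (4-methoxyphenyl in place of 2-(trifluoromethoxy)phenyl on an aromatic nitrogen). In a functional assay on NCI-H460 cells (Homo sapiens) for inhibition, read by MTT assay, with a stated time of 72 h (a higher number here means a weaker inhibitor, a lower number a stronger inhibitor), compound 1 gives 290 nM, compound 2 gives 260 nM and compound 3 gives 4650 nM. Changing the end group gave a 16-fold higher number from compound 1 to compound 3 (1.21 log units; beyond the scatter). The change 4-methylpiperazin-1-yl in place of 4-methylpiperidin-1-yl on a saturated chain carbon, three bonds along the chain from an oxygen on an aromatic ring gave a 1.1-fold lower number from compound 1 to compound 2 (0.05 log units; within the scatter). The same change, (4-methylpiperazin-1-yl in place of 4-methylpiperidin-1-yl on a saturated chain carbon, three bonds along the chain from an oxygen on an aromatic ring), links compound 3 to compound 4, with the same surroundings at the place of change. Because a 1.1-fold lower number from compound 1 to compound 2 (0.05 log units; within the scatter) lay within the scatter, the step from compound 3 to compound 4 is expected to be about a 1.1-fold lower number from compound 3 to compound 4 (0.04 log units; within the scatter). Compound 4 is therefore estimated at 4200 nM, between 2000 nM and 9000 nM.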

Compound 4, half-maximal inhibitory concentration: 3660 nM
Compound 4: the middle estimate sits 1.1-fold (0.06 log units) above what was measured, and the stated range covers the measured number.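

In this assay, 4-methylpiperazin-1-yl in place of 4-methylpiperidin-1-yl gave a 1.3-fold lower number from compound 3 to compound 4 (0.10 log units; within the scatter), which matches the same change on the other core: the same change on two cores in this assay, a 1.1-fold lower number (0.05 log units; within the scatter) from compound 1 to compound 2 and a 1.3-fold lower number (0.10 log units; within the scatter) from compound 3 to compound 4, 1.1-fold (0.06 log units) apart, within the scatter of two such steps. Likewise, 4-methoxyphenyl in place of 2-(trifluoromethoxy)phenyl gave a 14-fold higher number from compound 2 to compound 4 (1.15 log units; beyond the scatter), which also carried over: the same change on two cores in this assay, a 16-fold higher number (1.21 log units; beyond the scatter) from compound 1 to compound 3 and a 14-fold higher number (1.15 log units; beyond the scatter) from compound 2 to compound 4, 1.1-fold (0.06 log units) apart, within the scatter of two such steps. Among the compounds shown here, each change therefore behaved alike on both cores in these four compounds, but this rests on only two pairs per change and does not show that it would hold on other cores, or why the numbers move as they do.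

The compounds shown leave open how a 2-methoxyphenyl or 4-(trifluoromethoxy)phenyl group on that aromatic nitrogen would compare. They also leave open whether a morpholine at the end of the chain would give a step within the scatter.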